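Lengthening the Side Arm of a Serotonin Receptor Ligand

The compounds below may be only part of what the source reports. "The series", "measured", "known", "first", "only" and "open" are said of these compounds alone.

Of the compounds shown here, two have so far been measured in an assay on HEK293 cells for binding affinity to 5-hydroxytryptamine receptor 6 (Homo sapiens), with a stated time of 90 min, at pH 7.4; a lower number here means a stronger inhibitor, a higher number a weaker inhibitor. Compound 1 `CN(C)CCC1=C/C(=C\c2ccccc2)c2ccccc21` gives 57 nM in this assay. Compound 2 `CNCCC1=CC(Cc2ccccc2)c2ccccc21` gives 3 nM, the lowest of the two numbers, and its nearest neighbour, compound 1, sits well above it, far beyond the usual scatter of repeated measurements. Compound 3 `CNCCC1=CC(CCc2ccccc2)c2ccccc21` has not yet been measured in this assay. It differs from compound 2 in one place: benzyl in place of phenyl on a saturated chain carbon bound to a saturated ring carbon. The aromatic ring therefore sits on a longer link to the saturated ring carbon, while everything else in the molecule stays as it is in compound 2. Among the measured compounds shown here, no measured pair shows what such a lengthening does here, so the expectation rests only on compound 2 and on the modest size of the change. The expected step of a 2.7-fold higher number from compound 2 to compound 3 (0.43 log units; beyond the scatter) is small and points toward a weaker value, close to the edge of the scatter. Compound 3 is estimated to give about 8 nM in this assay, with a likely range from 2 nM to 30 nM.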

Compound 3, inhibition constant: 100 nM
Compound 3: the middle estimate sits 13-fold (1.10 log units) below what was measured; the whole stated range lies below it.
By their numbers in this assay, from the lowest: compound 2; then compounds 1 and 3 (each within the scatter of the next).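

In this assay, replacing phenyl with benzyl, on a saturated chain carbon bound to a saturated ring carbon, gives a 33-fold higher number from compound 2 to compound 3 (1.52 log units; beyond the scatter). Among the compounds shown here, this is the first measured change made in just one place, and it shows that affinity is highly sensitive to the length of the link to the aromatic ring: the entering and leaving groups each carry one six-membered aromatic ring of carbon only, have no hydrogen-bond donors or acceptors and have no net charge, yet much of the strength of compound 2 is lost. Nothing measured here explains the size of this step.

The compounds shown leave open whether a longer chain, such as phenylpropyl, would weaken binding further or level off, and whether a phenyl set directly on the saturated ring carbon would outperform or fall short of compound 2. They also leave open whether the longer link in compound 3 could be offset by a methoxy group or a fluorine atom on its aromatic ring, since neither group appears on that ring in any compound shown.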